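The compounds below may be only part of what the source reports. "The series", "measured", "known", "first", "only" and "open" are said of these compounds alone.

Measured so far, each value a limit of a functional assay on A549 cells (Homo sapiens) for inhibition, read by MTT assay, with a stated time of 24 h; a lower number here means a stronger inhibitor, a higher number a weaker inhibitor:
compound 1 `CCOC(=O)C1=Cc2ccccc2OC1(OCc1cc(-c2ccc3ccccc3c2)no1)C(F)(F)F` gives > 150000 nM, a limit.
compound 2 `O=C(O)C1=Cc2ccccc2OC1(OCc1cc(-c2ccc3ccccc3c2)no1)C(F)(F)F` gives > 150000 nM, a limit.
compound 3 `CCOC(=O)C1=Cc2ccccc2OC1(OCc1cn(-c2cccc(C(F)(F)F)c2)nn1)C(F)(F)F` gives > 150000 nM, a limit.

Compound 1 therefore stands only at a limit in this assay, and the two further values shown are limits as well (the limit of > 150000 nM in this assay, at which 3 of the 3 values shown sit). For the measured compounds named here, the one step between measured compounds, a step that the two limits leave unreadable from compound 1 to compound 2, has a limit at both ends and its size is not readable. Compound 4 `CCOC(=O)C1=Cc2ccccc2OC1(OCc1cc(-c2ccc(F)cc2)no1)C(F)(F)F` differs from compound 1 by 4-fluorophenyl in place of naphthalen-2-yl on an aromatic carbon. Going by the values given here, no measured step bears on this change. With every value at the limit, the expectation rests on compound 1 alone: compound 4 is estimated at 200000 nM, within 50000 nM to 1000000 nM. The expected step, a step that the limit leaves unreadable from compound 1 to compound 4, is taken as none beyond the scatter, most likely again a limit.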

Compound 4, half-maximal inhibitory concentration: 35500 nM
Compound 4: the middle estimate sits 5.6-fold (0.75 log units) above what was measured, and the stated range ends above it.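

In this assay, the aromatic carbon of the five-membered ring with 1 nitrogen and 1 oxygen proves sensitive to its substituent: 4-fluorophenyl in place of naphthalen-2-yl gives an at least 4.2-fold lower number from compound 1 to compound 4 (0.62 log units; beyond the scatter). The step has a limit at one end, so it gives only a minimum size. Compound 4 is the first value shown to come clear of the limit, which gives the series its first readable change: the limit of > 150000 nM in this assay, at which 3 of the 4 values shown sit.

On these data alone, it remains open whether the fluorine or the loss of the second aromatic ring carries the step. Unsubstituted phenyl or 4-aminophenyl at this position would bear on that question.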